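The compounds below may be only part of what the source reports. "The series", "measured", "known", "first", "only" and "open" are said of these compounds alone.

Of the compounds shown here, three sharing one core have been tested in a functional assay on HCT-116 cells (Homo sapiens) for antiproliferative activity, read by MTT assay, with a stated time of 48 h; a higher number here means a weaker inhibitor, a lower number a stronger inhibitor. Compound 1 `CCCCC(CCO)n1cnc2c(Cl)ncnc21` reads > 50000 nM, which is a limit of the assay and not a number. Compound 2 `CCCCCC(CCO)n1cnc2c(Cl)ncnc21` reads > 50000 nM, which is also a limit. Going by the values given here, compound 3 `CCCCCC(CCO)n1c(Br)nc2c(Cl)ncnc21` gives 18300 nM, the only true number in the set. The remaining results sit at one ceiling: the limit of > 50000 nM in this assay, at which 2 of the 3 values shown sit.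

Compound 4 `CCCCCCC(CCO)n1c(Br)nc2c(Cl)ncnc21` is built from compound 3 by one small edit, methyl in place of hydrogen on a saturated chain carbon, six bonds along the chain from an aromatic nitrogen.

Among the compounds with values here, the closest precedent is the same kind of edit made five bonds along the chain, but it offers no size to borrow, as it is a step that the two limits leave unreadable from compound 1 to compound 2. Within the data shown here, the one readable change, bromo in place of hydrogen on an aromatic carbon, is an at least 2.7-fold lower number from compound 2 to compound 3 (0.43 log units; beyond the scatter), but it is a different edit at a different place. With no measured size for a chain edit, no shift beyond the scatter is expected in this assay. The estimated change is a 1.2-fold lower number from compound 3 to compound 4 (0.09 log units; within the scatter). For compound 4 the expected value is 15000 nM, with an estimated range of 6000 nM to 40000 nM.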

Compound 4, half-maximal inhibitory concentration: 16100 nM
Compound 4: the middle estimate sits 1.1-fold (0.03 log units) below what was measured; measured number inside the range.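

In this assay, methyl in place of hydrogen on a saturated chain carbon, six bonds along the chain from an aromatic nitrogen, gives a 1.1-fold lower number from compound 3 to compound 4 (0.06 log units; within the scatter), which makes this the first chain edit in the series with a readable size, and that size cannot be told apart from the usual scatter of repeated measurements. The same kind of edit made five bonds along the chain, from compound 1 to compound 2, cannot be read because both compounds rest on one ceiling: the limit of > 50000 nM in this assay, at which 2 of the 4 values shown sit. With bromo on the shared core, compound 3 and compound 4 both give true numbers, so this pair shows that the chain can take this one added methyl with no measurable effect on the reading, though one pair says nothing about chain length in general.

As far as these compounds go, whether a still longer chain would also leave the reading level, or whether an amine or a carboxylic acid on the chain would shift it, remains open. From the compounds shown here alone, it is also open whether iodo or a methoxy group in the place of bromo would give a lower number than bromo does.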